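One Double Bond Flipped: From Compound 3 to Compound 4

A few compounds are considered here, and "the series" means these few. Any claim that something is new, unique, unknown or untested is made for them only; others in the source may bear on it.

Compound 3 `CC1=C(O)/C(=C\[C@H](C)CC/C=C(/C)CCCc2coc(Cc3ccoc3)c2)OC1=O` is tested in a functional assay on SK-MEL-2 cells (Homo sapiens) for cytotoxicity (a higher number here means that more compound is needed for the effect, a lower number that less compound is needed), where compound 3 gives 8.37 ug/mL. Within the data shown here, of the two numbers measured so far, compound 2 `CC1=C(O)[C@H](C/C(C)=C\CCC(C)/C=C\C=C(\C)CCCc2ccoc2)OC1=O` gives 7.78 ug/mL, which lies within the usual scatter of the value for compound 3. Compound 1 `CC1=C(O)[C@@H](C/C(C)=C\CCC(C)/C=C/C=C(\C)CCCc2ccoc2)OC1=O` gives only a limit, > 30 ug/mL. Among the measured compounds shown here, the sole measured step with a change in drawn configuration, an at least 3.8-fold lower number from compound 1 to compound 2 (0.58 log units; beyond the scatter), is known only as a bound because of the limit of > 30 ug/mL in this assay, at which 1 of the 3 values shown sits, and it bundled three stereo changes at once.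

Compound 4 `CC1=C(O)/C(=C/[C@H](C)CC/C=C(/C)CCCc2coc(Cc3ccoc3)c2)OC1=O` differs from compound 3 by a single flip: the two compounds have the same atoms and bonds and differ only in configuration as drawn: 1 of 3 stereo elements differ; a double bond is drawn E in compound 3 and Z in compound 4. For the measured compounds named here, since the only comparable step mixed several changes, it bears loosely on this one. I expect a step of a 1.0-fold lower number from compound 3 to compound 4 (0.02 log units; within the scatter), likely within the scatter, and estimate compound 4 at 8 ug/mL, ranging from 3 ug/mL to 25 ug/mL.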

Compound 4, concentration for half-maximal effect: 5.87 ug/mL
Compound 4: the middle estimate sits 1.4-fold (0.13 log units) above what was measured; measured number inside the range.
By their numbers in this assay, from the lowest: compounds 4, 2 and 3 (each within the scatter of the next). At a limit, above all of these: compound 1.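

In this assay the flip of this one double bond gives a 1.4-fold lower number from compound 3 to compound 4 (0.15 log units; within the scatter) and nothing else changes, unlike the earlier step, which bundled three stereo changes. Taken alone, the geometry at this double bond does not move the number beyond the scatter in this pair, and the step can be read cleanly: the fact that compounds 3 and 4 differ only in the configuration as drawn.

As far as these compounds go, the stereocentre and the other double bonds remain open on their own, having changed only together between compound 1 and compound 2. Also open, from the compounds shown here alone, is what an amine or a carboxylic acid on the shared core would do to the number.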